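Exchanging the Ring Group on Compound 3

The compounds below may be only part of what the source reports. "The series", "measured", "known", "first", "only" and "open" are said of these compounds alone.

In a functional assay on MIA PaCa-2 cells (Homo sapiens) for inhibition, read by MTT assay, with a stated time of 72 h (a higher number here means a weaker inhibitor of growth, a lower number a stronger inhibitor of growth), compound 3 `O=S(=O)(NCCCNCc1ccccc1Cl)c1cc(C(F)(F)F)cc(C(F)(F)F)c1` gives 11000 nM, the highest of the three measured numbers. Compound 1 `COc1ccc(CNCCCNS(=O)(=O)c2cc(C(F)(F)F)cc(C(F)(F)F)c2)cc1OC` gives 2800 nM and compound 2 `COc1cccc(CNCCCNS(=O)(=O)c2cc(C(F)(F)F)cc(C(F)(F)F)c2)c1` gives 3400 nM; the steps of a 3.9-fold higher number from compound 1 to compound 3 (0.59 log units; beyond the scatter) and a 3.2-fold higher number from compound 2 to compound 3 (0.51 log units; beyond the scatter) are both beyond the scatter, while a 1.2-fold higher number from compound 1 to compound 2 (0.08 log units; within the scatter) lies within it. Compound 4 `O=S(=O)(NCCCNCc1ccc(Cl)c(C(F)(F)F)c1)c1cc(C(F)(F)F)cc(C(F)(F)F)c1` differs from compound 3 by 4-chloro-3-(trifluoromethyl)phenyl in place of 2-chlorophenyl on a saturated chain carbon bound to an amine nitrogen. Within the data shown here, no measured step involves a trifluoromethyl at this position, so the only guidance is that exchanging the group on the saturated chain carbon bound to an amine nitrogen has moved the number modestly. Compound 4 is therefore expected to fall back toward the lower measured numbers, an expected step of a 2.2-fold lower number from compound 3 to compound 4 (0.34 log units; beyond the scatter). The estimate for compound 4 is 5000 nM, within 2000 nM to 14000 nM.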

Compound 4, concentration for 50% growth inhibition: 7400 nM
Beside the measured number, compound 4's estimate is 1.5-fold (0.17 log units) below it, and the stated range covers the measured number.
By their numbers in this assay, from the lowest: compounds 1 and 2 (each within the scatter of the next); then compounds 4 and 3 (each within the scatter of the next).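

In this assay, the 4-chloro-3-(trifluoromethyl)phenyl group cannot be told apart from 2-chlorophenyl on the saturated chain carbon bound to an amine nitrogen, since a 1.5-fold lower number from compound 3 to compound 4 (0.17 log units; within the scatter) lies within the scatter. Both chlorine-bearing groups give higher numbers than the methoxy-bearing groups, with no compound shown going against this: a 2.2-fold higher number from compound 2 to compound 4 (0.34 log units; beyond the scatter) and a 2.6-fold higher number from compound 1 to compound 4 (0.42 log units; beyond the scatter) both lie beyond the scatter. Nothing available accounts for this difference. Going by these compounds, whether a nitrile in place of the chlorine would keep the number at this level stays open, as does the effect of a longer chain on the shared core.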